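This account rests on a few compounds, and the source may have more. Where it says the series, first, only, none or still open, it means among the compounds named here.

Working notes on the series. The shared core of compound 1 `N#CCCSC(=S)NCc1cccnc1` carries a chain ending in a nitrile, and in a functional assay on Bel-7402 cells (Homo sapiens) for cytotoxicity, read by resazurin assay, with a stated time of 72 h (on this read-out higher numbers stand for weaker inhibition and lower numbers for stronger inhibition), compound 1 gives 1030 nM. Compound 2 `CC(=O)CCSC(=S)NCc1cccnc1` carries an acetyl at that chain end instead, and in this assay compound 2 gives 3430 nM. Compound 3 `O=C(O)CCSC(=S)NCc1cccnc1` carries a carboxy there, and in this assay compound 3 gives 7420 nM, the highest number of the three: the step of a 2.2-fold higher number from compound 2 to compound 3 (0.34 log units; beyond the scatter) and the step of a 7.2-fold higher number from compound 1 to compound 3 (0.86 log units; beyond the scatter) both run upward to it, and the step of a 3.3-fold higher number from compound 1 to compound 2 (0.52 log units; beyond the scatter) lies between.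

Compound 4 `CCCCOC(=O)CCSC(=S)NCc1cccnc1` differs from compound 3 by butyl in place of hydrogen on an oxygen next to a carbonyl group. Among the measured compounds shown here, no measured step covers an ester, so the nearest guide is the reverse of the step from compound 2 to compound 3, where removing the hydroxy on the carbonyl carbon went with a lower number, and the step from compound 1 to compound 3 points the same way. A moderate downward step is therefore expected, estimated as a 2.7-fold lower number from compound 3 to compound 4 (0.42 log units; beyond the scatter), with wide uncertainty since no ester is yet on record. Compound 4 is estimated at 2800 nM, with a range from 900 nM to 7500 nM.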

Compound 4, half-maximal inhibitory concentration: 6350 nM
The estimate for compound 4 lay 2.3-fold (0.36 log units) below the measured number, within the range that was stated.
By their numbers in this assay, from the lowest: compound 1; then compounds 2, 4 and 3 (each within the scatter of the next, the first and the last beyond it).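

In this assay, butyl in place of hydrogen on an oxygen next to a carbonyl group leaves the result within the scatter, with a 1.2-fold lower number from compound 3 to compound 4 (0.07 log units; within the scatter), so this change does not separate the butyl ester from the carboxylic acid. Going from the ketone to the ester also stays within the scatter, with a 1.9-fold higher number from compound 2 to compound 4 (0.27 log units; within the scatter), so the ester cannot be told from either the ketone or the acid, even though those two are printed as lying beyond the scatter of each other. No measurement on hand offers an explanation for these results.

As far as these compounds go, whether a methyl ester or a longer alkyl ester would read the same at this oxygen remains open. So does whether an amide or an amine at the chain end would approach the number of the nitrile, compound 1, at 1030 nM.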